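Mirror Image of a Weak Nicotinic Antagonist

The compounds below may be only part of what the source reports. "The series", "measured", "known", "first", "only" and "open" are said of these compounds alone.

compound 1 `O=C(NCc1cccc2ccccc12)c1ccccc1-c1ccccc1` > 100000 nM
compound 2 `C[C@@H]1CC(=O)N(c2ccccc2C(=O)OC[C@@H]2CCCN(CCCc3ccccc3)C2)C1=O` 9550 nM

Going by the values given here, in an in vitro functional assay on HEK ts201 cells for antagonist activity at Neuronal acetylcholine receptor; alpha3/beta4 (Homo sapiens), read by fluorescence and calcium flux (a lower number here means a stronger inhibitor, a higher number a weaker inhibitor), compound 2 gives 9550 nM, the only plain number in this set. For compound 1 the result is a limit, > 100000 nM, which is the limit of > 100000 nM in this assay, at which 1 of the 2 values shown sits. Compound 3 `C[C@H]1CC(=O)N(c2ccccc2C(=O)OC[C@H]2CCCN(CCCc3ccccc3)C2)C1=O` differs from compound 2 in that (the two compounds have the same atoms and bonds and differ only in configuration as drawn: 2 of 2 stereo elements differ (all stereocentres are inverted: mirror images); a stereocentre at a saturated ring carbon is drawn R in compound 2 and S in compound 3; a stereocentre at a saturated ring carbon is drawn R in compound 2 and S in compound 3). Among the compounds with values here, no step between measured compounds shows how inverting both centres acts here, so the direction stays open. The expected step is a 1.6-fold higher number from compound 2 to compound 3 (0.20 log units; within the scatter), a modest shift toward weaker inhibition carrying a wide spread. Compound 3 is expected to give 15000 nM, between 3000 nM and 80000 nM.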

Compound 3, half-maximal inhibitory concentration: 11000 nM
For compound 3 the middle estimate is 1.4-fold (0.13 log units) above the measured one, within the range that was stated.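

Inverting both stereocentres gives a 1.2-fold higher number from compound 2 to compound 3 (0.06 log units; within the scatter) in this assay and so the two mirror images read alike. Taken together, the two centres show no measurable preference for either configuration at this receptor, something the earlier compounds could not show, since neither had a partner differing in one place. As far as these compounds go, what inverting one centre alone would do stays open, since both change together here. Also open, from the compounds shown here alone, is whether a benzyl group or a longer chain in place of the phenylpropyl group would make the mirror images read apart.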